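Fluoro in place of bromo on compound 2

This account rests on a few compounds, and the source may have more. Where it says the series, first, only, none or still open, it means among the compounds named here.

Measured in a functional assay on T98G cells (Homo sapiens) for inhibition, read by MTT assay, with a stated time of 72 h (on this read-out lower numbers stand for stronger inhibition and higher numbers for weaker inhibition), so far:
compound 1 `COc1ccc(NC(=S)NC2CC(C)(C)Oc3ccc(Br)cc32)cc1` gives 33000 nM
compound 2 `CC1(C)CC(NC(=S)Nc2ccc([N+](=O)[O-])cc2)c2cc(Br)ccc2O1` gives 5000 nM
compound 3 `CC1(C)CC(NC(=S)Nc2ccc(Cl)cc2)c2cc(Br)ccc2O1` gives 22000 nM

Of the three, compound 2 has the lowest number, with both of its steps beyond the scatter. Next is compound 4 `CC1(C)CC(NC(=S)Nc2ccc([N+](=O)[O-])cc2)c2cc(F)ccc2O1`, with fluoro in place of bromo on an aromatic carbon. All measured compounds keep the bromo. Their steps, a 6.6-fold lower number from compound 1 to compound 2 (0.82 log units; beyond the scatter), a 4.4-fold higher number from compound 2 to compound 3 (0.64 log units; beyond the scatter) and a 1.5-fold lower number from compound 1 to compound 3 (0.18 log units; within the scatter), each replace a different group, so they offer only indirect guidance on this swap. No step beyond the scatter is expected in this assay, in either direction. The expected change is a 1.2-fold higher number from compound 2 to compound 4 (0.08 log units; within the scatter), with wide uncertainty. For compound 4 the estimated value is 6000 nM, with an expected range of 2000 nM to 18000 nM.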

Compound 4, half-maximal inhibitory concentration: 5000 nM
Estimate against measurement, compound 4: 1.2-fold (0.08 log units) above; the range from low to high includes it.
By their numbers in this assay, from the lowest: compounds 2 and 4 (each within the scatter of the next); then compounds 3 and 1 (each within the scatter of the next).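

In this assay fluoro in place of bromo gives no change at the digits printed from compound 2 to compound 4 (within the scatter) with the nitro kept. For the compounds shown here, the bromo of the earlier compounds is therefore not required at this aromatic carbon for this reading, a point those compounds could not address while all carried it. No measurement shown here speaks to why the two halogens read alike.

Going by these compounds alone, the swap is seen only on the nitro compounds, so its outcome with the methoxy or chloro groups stays open. Also open, on these data alone, is how an amine or a carboxylic acid would read at this aromatic carbon.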